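The compounds below may be only part of what the source reports. "The series", "measured", "known", "first", "only" and "open" are said of these compounds alone.

Measured so far in a functional assay (strain AB) with Danio rerio as the target, read by microscopy, with a stated time of 1 h; a higher number here means that more compound is needed for the effect, a lower number that less compound is needed:
- compound 1 `CN1CCc2c(sc(NC(=O)Nc3ccc(Cl)cc3)c2C(N)=O)C1` gives 4700 nM
- compound 2 `NC(=O)c1c(NC(=O)Nc2ccc(Cl)cc2)sc2c1CCN(CC1CCCCC1)C2` gives 1890 nM
- compound 3 `CC(C)(C)OC(=O)CCN1CCc2c(sc(NC(=O)Nc3ccc(Cl)cc3)c2C(N)=O)C1` gives 1100 nM

Compound 3 sits at the low end of these numbers. Its two steps are a 4.3-fold lower number from compound 1 to compound 3 (0.63 log units; beyond the scatter) and a 1.7-fold lower number from compound 2 to compound 3 (0.24 log units; within the scatter), so it is separated from compound 1 but not from compound 2.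

The next compound is compound 4 `CC(C)CN1CCc2c(sc(NC(=O)Nc3ccc(Cl)cc3)c2C(N)=O)C1`, with isopropyl in place of (tert-butoxycarbonyl)methyl on a saturated chain carbon bound to an amine nitrogen in a ring. The counted difference is isopropyl in place of (tert-butoxycarbonyl)methyl on a saturated chain carbon bound to an amine nitrogen in a ring and it leaves the rest of the structure unchanged.

Two measured steps at this place bear on the change. Cyclohexyl in place of hydrogen gave a 2.5-fold lower number from compound 1 to compound 2 (0.40 log units; beyond the scatter) and (tert-butoxycarbonyl)methyl in place of hydrogen gave a 4.3-fold lower number from compound 1 to compound 3 (0.63 log units; beyond the scatter), both modest. Isopropyl is the smallest of the three groups by heavy atoms, and no measured compound carries it. Compound 4 is therefore expected to fall among the values of the series, probably keeping only part of the gain seen over compound 1.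

A modest move to a higher number is expected, estimated as a 2.2-fold higher number from compound 3 to compound 4 (0.34 log units; beyond the scatter) in this assay overall. For compound 4 the expected value is 2400 nM, with an estimated range from 1000 nM to 5500 nM here.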

Compound 4, half-maximal effective concentration: 4510 nM
Compound 4: middle estimate off by 1.9-fold (0.27 log units), on the low side, and the stated range covers the measured number.
By their numbers in this assay, from the lowest: compounds 3 and 2 (each within the scatter of the next); then compounds 4 and 1 (each within the scatter of the next).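

In this assay, isopropyl in place of hydrogen on a saturated chain carbon bound to an amine nitrogen in a ring gives a 1.0-fold lower number from compound 1 to compound 4 (0.02 log units; within the scatter) and therefore no separation from the unsubstituted parent, so substitution at this place does not by itself bring the lower number. The separation belongs to the two larger groups, since cyclohexyl to isopropyl gives a 2.4-fold higher number from compound 2 to compound 4 (0.38 log units; beyond the scatter) and (tert-butoxycarbonyl)methyl to isopropyl gives a 4.1-fold higher number from compound 3 to compound 4 (0.61 log units; beyond the scatter) while compound 2 and compound 3 remain within the scatter of each other. Among these four compounds, lower numbers go with the two larger groups, with compound 4 as the one substituted compound that does not share them, and no measurement at hand explains this.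

With one compound each, the ring of cyclohexyl and the ester of the (tert-butoxycarbonyl)methyl group cannot be told apart as the feature that matters. A carboxylic acid in place of the tert-butyl ester, a longer unbranched alkyl chain or a benzyl group at this place would show whether the lower numbers follow group size or a particular kind of group.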